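This account rests on a few compounds, and the source may have more. Where it says the series, first, only, none or still open, it means among the compounds named here.

Working notes on the series, read in an ADME assay on BJ cells (Homo sapiens) for cytotoxicity, with a stated time of 72 h (on this read-out lower numbers stand for an effect already at smaller amounts and higher numbers for an effect only at larger amounts of compound), throughout. Compound 1 (`C=C[C@](C)(CCCC(C)C)CCc1ccc(O)cc1`) gives > 36600 nM as a limit of the assay. Compound 2 (`C=C[C@@](C)(/C=C/c1ccc(O)cc1)CCC(O)C(C)(C)O`) gives > 36600 nM as a limit as well. Compound 3 (`C=C[C@@](C)(/C=C/c1ccc(O)c(/C=C/C(=O)c2ccccc2)c1)CCC=C(C)C`) gives > 20000 nM and this too is a limit, not a number. For the measured compounds named here, compound 3 therefore stands with the other two at a limit, none of the three has a numerical value, and no pair among them differs in a single place. Going by the values given here, the series so far offers no measured step to scale a single change.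

Compound 4 (`C=C[C@@](C)(/C=C/c1ccc(O)c(/C=C/c2ccc(F)cc2)c1)CCC=C(C)C`) has not been measured. It carries 4-fluorophenyl in place of benzoyl on a double-bonded chain carbon bound to a double-bonded chain carbon, and the count of that change reads 4-fluorophenyl in place of benzoyl on a double-bonded chain carbon bound to a double-bonded chain carbon for the pair of compound 3 and compound 4. With compound 3 at > 20000 nM as its limit, no step beyond the scatter is expected in either direction in this assay for this exchange. The estimate means a step that the limit leaves unreadable from compound 3 to compound 4 as an expected change and no more than that. For compound 4 the estimated value is 25000 nM with an expected range from 10000 nM to 40000 nM and a report as a limit is the likelier outcome.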

Compound 4, half-maximal effective concentration: > 36600 nM
Compound 4 gave a limit, no number (the forecaster's own chance of this, stated with the estimate: 75%); at least 1.4-fold (0.16 log units) between middle value and limit.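

Compound 3 and compound 4 both stand at limits, not numbers, and no step can be read between them for 4-fluorophenyl in place of benzoyl. The compounds shown leave open which structural change, if any, would bring a numerical value in this assay, as all four stand at limits.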